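The source may report more compounds than this note shows. Statements on the series, on what has been measured and on what is new or still open speak of the compounds shown alone.

Working notes on the series. For the measured compounds named here, the three measured members share one core. Compound 3 `Cc1ccc(-c2cn(C[C@H](O)[C@H]3OC(=O)C(OCc4ccccc4)=C3OCc3ccccc3)nn2)cc1` carries 4-methylphenyl, compound 1 `O=C1O[C@H]([C@@H](O)Cn2cc(-c3cc(F)cc(F)c3)nn2)C(OCc2ccccc2)=C1OCc1ccccc1` carries 3,5-difluorophenyl, and compound 2 `O=C1O[C@H]([C@@H](O)Cn2cc(CNS(=O)(=O)c3ccc(Cl)cc3F)nn2)C(OCc2ccccc2)=C1OCc1ccccc1` carries a side chain of the same kind as that of the unmeasured member below. In a functional assay on HeLa cells (Homo sapiens) for antiproliferative activity, read by MTT assay, with a stated time of 72 h (a higher number here means a weaker inhibitor, a lower number a stronger inhibitor), compound 3 gives 25500 nM, compound 1 gives 40800 nM and compound 2 gives 20700 nM. Compound 3 stands second highest of the three numbers; its nearest is compound 2 and its furthest is compound 1, both within the scatter. Going by the values given here, the single step so far, a 1.6-fold lower number from compound 1 to compound 3 (0.20 log units; within the scatter), is also within the scatter.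

Compound 4 `O=C1O[C@H]([C@@H](O)Cn2cc(CNS(=O)(=O)c3ccc(Cl)cc3)nn2)C(OCc2ccccc2)=C1OCc1ccccc1` differs from compound 3 by (((4-chlorophenyl)sulfonyl)amino)methyl in place of 4-methylphenyl on an aromatic carbon. Among the compounds with values here, no measured step covers this exchange directly; the only bearing comes from the side chain of compound 4, which closely resembles that of compound 2. In this assay compound 2 gives 20700 nM, a value within the scatter of that of compound 3. Nothing beyond the scatter is therefore expected in this assay. Compound 4 is estimated at 22000 nM, with a range from 8000 nM to 60000 nM. The expected step of a 1.2-fold lower number from compound 3 to compound 4 (0.06 log units; within the scatter) is accordingly small.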

Compound 4, half-maximal inhibitory concentration: 13600 nM
For compound 4 the middle estimate is 1.6-fold (0.21 log units) above the measured one; low and high end bracket the measured number.
By their numbers in this assay, from the lowest: compounds 4, 2, 3 and 1 (each within the scatter of the next, the first and the last beyond it).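

In this assay, for the compounds shown here, this position on the five-membered aromatic ring now gives a first step beyond the scatter: (((4-chlorophenyl)sulfonyl)amino)methyl in place of 3,5-difluorophenyl (a 3.0-fold lower number from compound 1 to compound 4 (0.48 log units; beyond the scatter)). The same side chain in place of 4-methylphenyl stays within the scatter (a 1.9-fold lower number from compound 3 to compound 4 (0.27 log units; within the scatter)), as does hydrogen in place of fluoro on the aromatic ring of that side chain (a 1.5-fold lower number from compound 2 to compound 4 (0.18 log units; within the scatter)), so the change reads as modest and depends on the group it replaces. Nothing at hand accounts for these steps.

The compounds shown leave open how a carboxamide in place of the sulfonyl group, or a longer chain in place of the single methylene, would read in this assay. They also leave open whether a free amine on the side chain's aromatic ring would move the number beyond the scatter.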